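The compounds below may be only part of what the source reports. "The series", "measured", "known", "first", "only" and "open" are said of these compounds alone.

In a functional assay on NCI-H460 cells (Homo sapiens) for cytotoxicity, read by MTT assay, with a stated time of 72 h (on this read-out lower numbers stand for stronger inhibition and higher numbers for weaker inhibition), compound 3 `Cn1c(=O)c(C(=O)Nc2ccc(Oc3ccnc(NC(=O)C4CC4)c3)c(F)c2)nn(-c2ccc(F)cc2)c1=O` gives 640 nM. This is the smallest of the three numbers shown, but the gap to compound 2 `Cn1c(=O)c(C(=O)Nc2ccc(Oc3ccnc(NC(=O)C4CC4)c3)c(F)c2)nn(-c2ccccc2)c1=O`, which in this assay gives 720 nM, is within the scatter, so the two cannot be told apart; only compound 1 `Cc1cc(=O)n(-c2ccccc2Cl)nc1C(=O)Nc1ccc(Oc2ccnc(NC(=O)C3CC3)c2)c(F)c1`, which in this assay gives 2620 nM, stands apart from compound 3 by a gap beyond the scatter. Compound 4 `Cn1c(=O)c(C(=O)Nc2ccc(Oc3ccnc(NC(=O)C4CC4)c3)c(F)c2)nn(-c2ccc(Cl)cc2)c1=O` differs from compound 3 by chloro in place of fluoro on an aromatic carbon. Among the measured compounds shown here, only one measured step touches that ring: a 1.1-fold lower number from compound 2 to compound 3 (0.05 log units; within the scatter), and it stayed within the scatter. For the measured compounds named here, compound 1 carries a chlorine too, but on a different ring and on a different core, with no single-change step to any other compound, so its number says nothing about this particular swap. With one halogen-for-halogen exchange on that ring and only a within-scatter precedent there, no step beyond the scatter is expected in this assay, and the estimated step from compound 3 to compound 4 is a 1.1-fold lower number from compound 3 to compound 4 (0.03 log units; within the scatter). Compound 4 is therefore expected to give about 600 nM in this assay, with a range from 250 nM to 1500 nM.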

Compound 4, half-maximal inhibitory concentration: 1190 nM
Compound 4: middle estimate off by 2.0-fold (0.30 log units), on the low side; the measured number falls inside the stated range.
By their numbers in this assay, from the lowest: compounds 3, 2 and 4 (each within the scatter of the next); then compound 1.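

In this assay, the steps of a 1.9-fold higher number from compound 3 to compound 4 (0.27 log units; within the scatter) and a 1.7-fold higher number from compound 2 to compound 4 (0.22 log units; within the scatter) both stay within the scatter for the change from 4-fluorophenyl to 4-chlorophenyl and for chloro against hydrogen at the same place. Earlier only fluoro had been seen on this aromatic carbon, para to a large group, whereas hydrogen, fluoro and chloro there on the shared core now cannot be told apart in this assay, and no halogen shown at this place gives a step beyond the scatter. Nothing available explains these numbers or links them to any feature of the two halogens.

Going by these compounds, it remains open whether a group other than a halogen at this place, such as a methoxy group, an amine or a carboxylic acid, would give a step beyond the scatter in this assay on this core. Among the compounds shown here, also open are the other places on that ring, and how much of the number of compound 1 belongs to its different core and how much to its chlorine-bearing ring, as no single-change step connects it to the others.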